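This account rests on a few compounds, and the source may have more. Where it says the series, first, only, none or still open, it means among the compounds named here.

Measured so far:
compound 1, `CCc1ccc2nc(C(=O)Nc3c(F)cc(-c4cccc(F)c4)cc3F)c(C)c(O)c2c1`, 46.3%
compound 2, `Cc1c(C(=O)Nc2c(F)cc(-c3cccc(F)c3)cc2F)nc2ccc(F)cc2c1O`, 31.3%
compound 3, `Cc1c(C(=O)Nc2c(F)cc(-c3cccc(F)c3)cc2F)nc2ccc(OC(F)(F)F)cc2c1O`, 37.9%

These three compounds were tested in a functional assay on Hep 3B2 cells (Homo sapiens) for antiproliferative activity, read by MTT assay, with a stated time of 24 h, tested at 11.11 ug/mL; on this read-out higher numbers stand for a stronger effect at the one concentration tested and lower numbers for a weaker effect. Compound 1 gives the highest of the three numbers. Its nearest neighbour is compound 3, which lies a number 8.4 percentage points lower from compound 1 to compound 3 (within the scatter), a gap that stays within the scatter. The furthest is compound 2, with a number 15 percentage points lower from compound 1 to compound 2 (beyond the scatter), a gap that goes beyond it. Between compound 2 and compound 3 the step is a number 6.6 percentage points higher from compound 2 to compound 3 (within the scatter), again within the scatter.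

Compound 4, `CCc1ccc2nc(C(=O)Nc3c(F)cc(-c4cccc(F)c4)cc3F)c(C)c(C(=O)O)c2c1`, has not been measured. It differs from compound 1 in one place: carboxy in place of hydroxy on an aromatic carbon. Among the compounds with values here, the measured steps all concern the ethyl group and what replaces it; not one of them touches the hydroxy group, so no measured step bears directly on this change. The expectation therefore rests on compound 1 alone, with wide uncertainty. The step of a number 6.3 percentage points lower from compound 1 to compound 4 (within the scatter) is estimated as not beyond the scatter. Compound 4 is expected to give about 40%, within a range from 18% to 62%.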

Compound 4, a percentage reported as inhibition, at one concentration (the size of the read-out at that concentration, not a potency): 27.2%
Compound 4: middle estimate off by 12.8 percentage points, on the high side, within the range that was stated.
By their numbers in this assay, from the lowest: compounds 4, 2, 3 and 1 (each within the scatter of the next, the first and the last beyond it).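

Carboxy in place of hydroxy gives a number 19.1 percentage points lower from compound 1 to compound 4 (beyond the scatter) in this assay and so shows that the number responds to this position, opposite the ring nitrogen, and not only to the ethyl site changed in the earlier compounds. The change swaps 1 heavy atom for 3 heavy atoms while the counts of hydrogen-bond donors and acceptors stay the same, so the drop occurs without any difference in those counts. Nothing available here explains the drop.

With only carboxy and hydroxy shown at this position, it remains open whether a methoxy group, an amine or a methyl ester would keep the effect of compound 1 or lose it. Going by these compounds, it is also open whether this step would look the same at other concentrations, since each number comes from a single one.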